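Methyl for Hydrogen on an Oxygen, Across Two Cores

The compounds below may be only part of what the source reports. "The series", "measured", "known", "first", "only" and "open" are said of these compounds alone.

Compound 1 `O/N=C(\CCN1CCN(c2ccccn2)CC1)c1ccccc1Cl` gives in a functional assay on HEK293 cells with D(4) dopamine receptor (Homo sapiens) as the target, read by FLIPR (on this read-out higher numbers stand for larger maximal responses and lower numbers for smaller maximal responses), a value of 74%. Compound 2 `CO/N=C(\CCN1CCN(c2ccccn2)CC1)c1ccccc1Cl` differs from compound 1 by methyl in place of hydrogen on an oxygen, and in this assay compound 2 gives 79%; the step is a number 5 percentage points higher from compound 1 to compound 2 (within the scatter), so the two values stand within the usual scatter of each other.

Compound 3 `O/N=C(\CCCN1CCN(c2ccccn2)CC1)c1ccc(F)cc1` has a different core; the difference between the two cores is not broken down here. In this assay compound 3 gives 62%, the lowest of the three numbers, with compound 1 and compound 2 both beyond the scatter above it.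

Compound 4 `CO/N=C(\CCCN1CCN(c2ccccn2)CC1)c1ccc(F)cc1` is not yet measured. It differs from compound 3 by methyl in place of hydrogen on an oxygen, the same change as from compound 1 to compound 2, made at a place described in the same words; it occurs twice among the compounds shown. Among the measured compounds shown here, the step from compound 3 to compound 4 in this assay is expected to be small, because a number 5 percentage points higher from compound 1 to compound 2 (within the scatter) is the single earlier example of this change and is within the scatter. Compound 4 is therefore expected to give about 66%, between 55% and 78%, a step of a number 4 percentage points higher from compound 3 to compound 4 (within the scatter).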

Compound 4, largest response reached (reported as efficacy), in percent of the reference or control that the assay uses: 60%
Estimate against measurement, compound 4: 6 percentage points above; low and high end bracket the measured number.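

Hydroxy to methoxy, methyl in place of hydrogen on an oxygen whose other neighbour is a double-bonded nitrogen, again leaves the maximal response in this assay essentially in place on the second core, the step being a number 2 percentage points lower from compound 3 to compound 4 (within the scatter). Set beside the step on the first core, the two cannot be told apart: the same change on two cores in this assay, a number 5 percentage points higher (within the scatter) from compound 1 to compound 2 and a number 2 percentage points lower (within the scatter) from compound 3 to compound 4, 7 percentage points apart, within the scatter of two such steps. So on these two cores the change carries over without a step beyond the scatter, but two pairs in a single read-out do not show that it would behave the same way on any other core, or that it would leave other read-outs in place.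

The compounds shown hold only hydrogen and methyl on this oxygen, so an ethyl group, a benzyl group or a longer chain ending in an amine or a carboxylic acid remains open there. The difference between the two cores also remains open, as no pair among these compounds splits it into single changes.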